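Replacing the Aryl Group on the Amide Carbonyl

This account rests on a few compounds, and the source may have more. Where it says the series, first, only, none or still open, it means among the compounds named here.

Three compounds sharing one core differ only in the aryl group on the amide carbonyl. In a functional assay on GTL 16 cells for antiproliferative activity against GTL 16 cell line (Homo sapiens), read by CCK-8 assay, with a stated time of 72 h (on this read-out higher numbers stand for weaker inhibition and lower numbers for stronger inhibition), compound 2 `COc1cccc(C(=O)Nc2cccc(-c3oc4cc(-c5ccc(F)cc5)ccc4c(=O)c3O)c2)c1` gives 12500 nM, close to compound 3 `Cc1cccc(C(=O)Nc2cccc(-c3oc4cc(-c5ccc(F)cc5)ccc4c(=O)c3O)c2)c1` at 10900 nM and compound 1 `O=C(Nc1cccc(-c2oc3cc(-c4ccc(F)cc4)ccc3c(=O)c2O)c1)c1ccccc1F` at 17400 nM; all three numbers lie within the scatter of one another. Compound 4 `O=C(Nc1cccc(-c2oc3cc(-c4ccc(F)cc4)ccc3c(=O)c2O)c1)c1cc(F)cc(F)c1` keeps the core with a new aryl group: 3,5-difluorophenyl in place of 3-methoxyphenyl on a carbonyl carbon. The steps seen so far, a 1.4-fold lower number from compound 1 to compound 2 (0.14 log units; within the scatter), a 1.6-fold lower number from compound 1 to compound 3 (0.20 log units; within the scatter) and a 1.1-fold lower number from compound 2 to compound 3 (0.06 log units; within the scatter), were all within the scatter, so changing this aryl group has not moved the number noticeably. Among the compounds with values here, no measured compound carries 3,5-difluorophenyl; compound 1, whose ring also bears fluorine, gave 17400 nM. Compound 4 is therefore expected to give 13500 nM, within a range of 6000 nM to 30000 nM, an expected step of a 1.1-fold higher number from compound 2 to compound 4 (0.03 log units; within the scatter).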

Compound 4, half-maximal inhibitory concentration: 7410 nM
The estimate for compound 4 lay 1.8-fold (0.26 log units) above the measured number; measured number inside the range.
By their numbers in this assay, from the lowest: compounds 4, 3, 2 and 1 (each within the scatter of the next, the first and the last beyond it).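

Within the data shown here, the change to 3,5-difluorophenyl in this assay gives the first step at this position that lies beyond the scatter, though a modest one (a 2.3-fold lower number from compound 1 to compound 4 (0.37 log units; beyond the scatter)). The other two steps stay within the scatter (a 1.7-fold lower number from compound 2 to compound 4 (0.23 log units; within the scatter)) and (a 1.5-fold lower number from compound 3 to compound 4 (0.17 log units; within the scatter)), so compound 4 stands apart only from compound 1. Nothing measured here explains this difference.

Still open, on these data alone, is whether a cyclohexyl group or a longer chain in place of the aryl group, or an aryl group carrying an amine or a carboxylic acid, would move the number further.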